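The source may hold more compounds than are shown below. What is called first, only, known or untested is meant among the compounds shown, and "the series" means these compounds.

Compound 1 `C#Cc1cccc(Nc2ncnc3cc(OCCCCn4ccnc4[N+](=O)[O-])c(OC)cc23)c1` and compound 2 `C#Cc1cccc(Nc2ncnc3cc(OCCCCCn4ccnc4[N+](=O)[O-])c(OC)cc23)c1` share one core and differ in a single place: (2-nitro-1H-imidazol-1-yl)methyl in place of 2-nitro-1H-imidazol-1-yl on a saturated chain carbon, four bonds along the chain from an oxygen on an aromatic ring. In a functional assay on A549 cells (Homo sapiens) for inhibition, read by sulforhodamine B assay, with a stated time of 72 h (on this read-out higher numbers stand for weaker inhibition and lower numbers for stronger inhibition), compound 1 gives 1080 nM, and compound 2 gives 180 nM. That change produced a 6.0-fold lower number from compound 1 to compound 2 (0.78 log units; beyond the scatter), so lengthening the chain by one carbon went with stronger inhibition in this pair.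

Compound 3 `COc1cc2c(Nc3ccc(OCc4cccc(F)c4)c(Cl)c3)ncnc2cc1OCCCCCn1ccnc1[N+](=O)[O-]` rests on a different core; the difference between the two cores is not broken down here. In this assay compound 3 gives 14400 nM, the highest of the three numbers.

Compound 4 `COc1cc2c(Nc3ccc(OCc4cccc(F)c4)c(Cl)c3)ncnc2cc1OCCCCCCn1ccnc1[N+](=O)[O-]` is related to compound 3 by the same kind of change: (2-nitro-1H-imidazol-1-yl)methyl in place of 2-nitro-1H-imidazol-1-yl on a saturated chain carbon, five bonds along the chain from an oxygen on an aromatic ring. The place is not identical, since here the group sits five bonds along the chain from an oxygen on an aromatic ring rather than four.

Because compound 1 moved to compound 2 by a 6.0-fold lower number from compound 1 to compound 2 (0.78 log units; beyond the scatter), a lower number for compound 4 is expected, but since the core and the place both differ, a smaller step is estimated, a 2.4-fold lower number from compound 3 to compound 4 (0.38 log units; beyond the scatter). Compound 4 is therefore expected to give about 6000 nM, with a likely range from 2000 nM to 18000 nM.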

Compound 4, half-maximal inhibitory concentration: > 50000 nM
Compound 4: a limit, no number; the forecaster's own chance of this, stated with the estimate: 10%; middle value at least 8.3-fold (0.92 log units) from the limit.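

In this assay compound 4 gives > 50000 nM as a limit of the assay, not a number. Adding one carbon to the chain went with stronger inhibition on the core of compound 1, but on the core of compound 3 it went with weaker inhibition, as an at least 3.4-fold higher number from compound 3 to compound 4 (0.54 log units; beyond the scatter) shows, so the direction of this change did not carry over from one core to the other: the same change on two cores in this assay, a 6.0-fold lower number (0.78 log units; beyond the scatter) from compound 1 to compound 2 and an at least 3.4-fold higher number (0.54 log units; beyond the scatter) from compound 3 to compound 4, at least 20-fold (1.31 log units) apart, beyond the scatter of two such steps. This rests on a single pair per core and the chain lengths differ between the pairs, so it gives no rule for other cores, does not explain the reversal, and leaves the full size of the second step unknown.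

The compounds shown leave open whether a still longer chain on the core of compound 1 would keep lowering the number. They also leave open whether an amine in place of the 2-nitro-1H-imidazol-1-yl group would behave alike on both cores.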